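The compounds below may be only part of what the source reports. "The series", "measured", "known", "first", "only" and "open" are said of these compounds alone.

Compound 1 `C=C[C@](C)(O)CC[C@H]1C(C)=CC[C@H]2C(C)(C)CCC[C@]12C` is a diterpene alcohol with a free tertiary hydroxyl on its side chain. In a functional assay on XF498 cells (Homo sapiens) for cytotoxicity, read by sulforhodamine B assay (on this read-out higher numbers stand for an effect only at larger amounts of compound and lower numbers for an effect already at smaller amounts), compound 1 gives 9.5 ug/mL, and this is the only numerical result among the three measured compounds. Compound 2 `C=C[C@@](C)(CC[C@@H]1[C@@]2(C)CCCC(C)(C)[C@@H]2CC[C@@]1(C)O)O[C@H]1O[C@H](C)[C@H](O)[C@@H](O)[C@@H]1O`, which carries a sugar on that side-chain oxygen and an extra hydroxyl on its core, reaches only the limit > 5 ug/mL in this assay. Compound 3 `C=C[C@](C)(O)CC[C@H]1C(=C)[C@H](O)C[C@H]2C(C)(C)CCC[C@]12C`, which keeps the free side-chain hydroxyl but bears a hydroxyl and an exocyclic double bond on its core, likewise reaches only the limit > 5 ug/mL. The shared boundary the limit of > 5 ug/mL in this assay, at which 2 of the 3 values shown sit, is thus where most of the series sits.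

Compound 4 `C=C[C@@](C)(CC[C@H]1C(C)=CC[C@H]2C(C)(C)CCC[C@]12C)O[C@@H]1O[C@@H](C)[C@@H](O)[C@H](O)[C@H]1O` differs from compound 1 by a group of 10 heavy atoms (6 carbon, 4 oxygen; one six-membered non-aromatic ring with 1 hetero atom) in place of a hydrogen atom, on an oxygen on a saturated carbon. Such a sugar attachment is expected to shift the outcome toward weaker cytotoxicity, with the step of a 1.6-fold higher number from compound 1 to compound 4 (0.20 log units; within the scatter) expected to exceed the usual scatter. Compound 4 is therefore estimated to give 15 ug/mL, in the range from 6 ug/mL to 40 ug/mL.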

Compound 4, concentration for half-maximal effect: 8.9 ug/mL
Beside the measured number, compound 4's estimate is 1.7-fold (0.23 log units) above it; low and high end bracket the measured number.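

Putting a group of 10 heavy atoms, with one six-membered non-aromatic ring, in place of the hydrogen on an oxygen on a saturated carbon gives a 1.1-fold lower number from compound 1 to compound 4 (0.03 log units; within the scatter) in this assay. Among these compounds, this pair is the first to differ in one place, and it shows that the free hydroxyl hydrogen on this oxygen is not needed for the effect on these cells and that a group of this size is tolerated there. Nothing measured here explains why so large a change leaves the read-out within the scatter.

From the compounds shown here alone, whether a small methyl or acetyl group on this oxygen, or a sugar-sized group carrying an amine or a carboxylic acid, would behave the same stays open. Going by these compounds, what the core hydroxyl groups of compound 2 and compound 3 contribute also stays open, since both differ from compound 1 in more than one place and both values are limits of the assay.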